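Exchange on the ring amine: from compound 3 to compound 4

The source may report more compounds than this note shows. Statements on the series, on what has been measured and on what is new or still open speak of the compounds shown alone.

Compound 3 `CCCS(=O)(=O)N1CC=C(c2ccc3c(c2)CC(C2CCN(c4ccc(C(F)(F)F)cn4)CC2)O3)CC1` holds the highest number of the three measured in a functional assay on HEK293 cells with Glucose-dependent insulinotropic receptor (Homo sapiens) as the target, read by cAMP accumulation, with a stated time of 60 min (on this read-out higher numbers stand for larger maximal responses and lower numbers for smaller maximal responses), giving 99%. Compound 2 `CCCS(=O)(=O)N1CC=C(c2ccc3c(c2)CC(C2CCN(c4ncc(Cl)cn4)CC2)O3)CC1` gives 88%, and compound 1 `CCCS(=O)(=O)N1CC=C(c2ccc3c(c2)CC(C2CCN(C(=O)OC4CCCCC4)CC2)O3)CC1` gives 56%. The measured steps were a number 43 percentage points higher from compound 1 to compound 3 (beyond the scatter) and a number 32 percentage points higher from compound 1 to compound 2 (beyond the scatter), with the smaller a number 11 percentage points higher from compound 2 to compound 3 (beyond the scatter) separating the two members that carry a six-membered aromatic ring on this nitrogen. Compound 4 `CCCc1cnc(N2CCC(C3Cc4cc(C5=CCN(S(=O)(=O)CCC)CC5)ccc4O3)CC2)nc1` differs from compound 3 by 5-propylpyrimidin-2-yl in place of 5-(trifluoromethyl)pyridin-2-yl on an amine nitrogen in a ring. Among the measured compounds shown here, the step from compound 2 to compound 3 bears most directly, as both such rings gave high responses; no measured step covers a propyl chain on the ring. Compound 4 is therefore expected to stay near the top, with an estimated step of a number 7 percentage points lower from compound 3 to compound 4 (within the scatter), within the scatter. The estimate for compound 4 is 92%, between 78% and 105%.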

Compound 4, largest response reached (Emax), in percent of the reference or control that the assay uses: 107%
For compound 4 the middle estimate is 15 percentage points below the measured one; measured number outside the range, above it.
By their numbers in this assay, from the lowest: compound 1; then compound 2; then compounds 3 and 4 (each within the scatter of the next).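

Propyl in place of chloro on an aromatic carbon gives a number 19 percentage points higher from compound 2 to compound 4 (beyond the scatter) in this assay and so shows that this carbon accepts an alkyl chain with no loss of response. 5-Propylpyrimidin-2-yl in place of 5-(trifluoromethyl)pyridin-2-yl gives a number 8 percentage points higher from compound 3 to compound 4 (within the scatter) and the same ring in place of cyclohexyloxycarbonyl gives a number 51 percentage points higher from compound 1 to compound 4 (beyond the scatter) on this amine nitrogen. No evidence on the origin of these steps is at hand. On these data alone, whether a butyl chain, an isopropyl group or an amine on that carbon would hold the response stays open. Compound 3 and compound 4 differ in both ring and substituent, so the contribution of each stays unresolved.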